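The source may hold more compounds than are shown below. What is called first, only, known or untested is meant among the compounds shown, and "the series" means these compounds.

Compound 1 `C[C@H](c1ccccc1)N1C(=O)O[C@](Cc2ccccc2)(c2nc(-c3ccccc3)co2)C1=O` gives 73% in an ADME assay (liver) for metabolic stability, with Liver microsome (Homo sapiens) as the target, using microsomes, with a stated time of 0.5 h, tested at 1 uM; a lower number here means that less of the compound is left, a higher number that more of the compound is left.
Compound 2 `C[C@H](c1ccccc1)N1C(=O)O[C@](Cc2ccccc2)(c2ncc(-c3ccccc3)[nH]2)C1=O` gives 62% in this assay.
Compound 3 `C[C@H](c1ccccc1)N1C(=O)O[C@](Cc2ccccc2)(c2nnc(-c3ccccc3)[nH]2)C1=O` gives 78% in this assay.

The three compounds share one core and differ only in the five-membered aromatic ring that carries a phenyl group. Compound 3 shows the highest of the three numbers. Its distance to compound 1, a number 5 percentage points higher from compound 1 to compound 3 (within the scatter), lies within the scatter, so these two cannot be ordered; only its distance to compound 2, a number 16 percentage points higher from compound 2 to compound 3 (beyond the scatter), is beyond the scatter and counts as a modest step.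

Compound 4 `C[C@H](c1ccccc1)N1C(=O)O[C@](Cc2ccccc2)(c2nnc(-c3ccc(Cl)c(Cl)c3)[nH]2)C1=O` keeps the five-membered ring of compound 3 and changes the phenyl group on it: 3,4-dichlorophenyl in place of phenyl on an aromatic carbon. For the measured compounds named here, none of the measured steps touches this phenyl group; all of them swap the five-membered ring, as in a number 11 percentage points lower from compound 1 to compound 2 (beyond the scatter), and so none of them bears directly on the present change. Going by the values given here, the data therefore give no direction for this step, and the expectation for this assay is a step of no change at the digits printed from compound 3 to compound 4 (within the scatter), within the scatter, with a wider range than usual. Compound 4 is estimated at 78%, between 60% and 92%.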

Compound 4, percent of the compound remaining: 88%
Compound 4: the middle estimate sits 10 percentage points below what was measured; measured number inside the range.
By their numbers in this assay, from the lowest: compound 2; then compounds 1, 3 and 4 (each within the scatter of the next, the first and the last beyond it).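

For the compounds shown here, compound 4 is the first case here in which the group on the five-membered ring changes while that ring stays the same, and in this assay the result is a number 10 percentage points higher from compound 3 to compound 4 (within the scatter). Compound 3 and compound 4 therefore cannot be ordered, even though 3,4-dichlorophenyl brings two chlorine atoms that phenyl lacks, at this place on an aromatic carbon of a five-membered aromatic ring with 3 nitrogen. For this one pair, the larger group leaves the percentage of compound remaining without a change that can be told from repeat-measurement noise, and no separate measurement is available to explain this result.

From the compounds shown here alone, it remains open whether a single chlorine, a methoxy group or an amine on the same phenyl ring would give a clear step in either direction. Also open, going by these compounds, is whether 3,4-dichlorophenyl would behave the same way on the different five-membered rings of compound 1 and compound 2, where the numbers could respond differently to this change.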